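Swapping phenyl for benzyl on the ring nitrogen

This account rests on a few compounds, and the source may have more. Where it says the series, first, only, none or still open, it means among the compounds named here.

Measured compounds:
- compound 1 `Cc1nn(C)c2nc(C(C)C)c(/C=C/[C@@H](O)C[C@@H](O)CC(=O)O)c(-c3ccc(F)cc3)c12`: 48.1%
- compound 2 `Cc1nn(-c2ccccc2)c2nc(C(C)C)c(/C=C/[C@@H](O)C[C@@H](O)CC(=O)O)c(-c3ccc(F)cc3)c12`: 19.9%
- compound 3 `CC(C)c1nc2onc(-c3ccccc3)c2c(-c2ccc(F)cc2)c1/C=C/[C@@H](O)C[C@@H](O)CC(=O)O`: 52.3%

In an in vivo functional assay on the whole organism for inhibition of 3-hydroxy-3-methylglutaryl-coenzyme A reductase (Rattus norvegicus), at a dose of 2 mg/kg by the oral route (on this read-out higher numbers stand for a stronger effect at the one dose given and lower numbers for a weaker effect), compound 1 gives 48.1% and compound 3 gives 52.3%. Compound 2 gives 19.9%, the lowest of the three numbers, with both others standing beyond the scatter above it.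

Among the measured compounds shown here, the single comparable step is a number 28.2 percentage points lower from compound 1 to compound 2 (beyond the scatter), where phenyl replaced methyl on the aromatic nitrogen. Compound 4 `Cc1nn(Cc2ccccc2)c2nc(C(C)C)c(/C=C/[C@@H](O)C[C@@H](O)CC(=O)O)c(-c3ccc(F)cc3)c12` is not yet measured; it differs from compound 2 in one place: benzyl in place of phenyl on an aromatic nitrogen. Here the phenyl leaves and a benzyl enters at the same aromatic nitrogen. For the measured compounds named here, no measured pair shows phenyl against benzyl, so the expectation leans on the fact that the methyl-bearing compound 1 48.1% sits well above compound 2 19.9%. A benzyl is neither methyl nor phenyl, so a partial recovery is expected, with wide uncertainty: the estimated step is a number 13.1 percentage points higher from compound 2 to compound 4 (beyond the scatter). Compound 4 is therefore expected to give about 33%, in a range from 14% to 52%.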

Compound 4, a percentage reported as inhibition, in the whole organism at one dose (the size of the read-out at that dose, not a potency): 45.1%
Beside the measured number, compound 4's estimate is 12.1 percentage points below it; measured number inside the range.
By their numbers in this assay, from the lowest: compound 2; then compounds 4, 1 and 3 (each within the scatter of the next).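

In this assay the low read-out of compound 2 does not come simply from having a six-membered aromatic ring on this aromatic nitrogen: benzyl in place of phenyl gives a number 25.2 percentage points higher from compound 2 to compound 4 (beyond the scatter) even though the same ring is still present. Against compound 1, placing phenyl in place of hydrogen on a saturated chain carbon bound to the aromatic nitrogen gives a number 3 percentage points lower from compound 1 to compound 4 (within the scatter) and so leaves the read-out level within the usual scatter. Among these compounds, then, how the ring is attached to the nitrogen matters, not whether a ring is there.

The compounds shown leave open whether a longer chain such as phenethyl, or an amine or a carboxylic acid on the benzyl ring, would hold the read-out. Nothing here gives a reason for the difference between phenyl and benzyl.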